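Quinolinyl for pyridinyl phosphate esters on the fluorouracil series

The compounds below may be only part of what the source reports. "The series", "measured", "known", "first", "only" and "open" are said of these compounds alone.

Compound 1 `O=C(O[C@H]1C[C@H](n2cc(F)c(=O)[nH]c2=O)O[C@@H]1COP(=O)(O)Oc1cccnc1)c1ccccc1` gives 710 nM in a functional assay on U-87MG ATCC cells for cytotoxicity against U-87 MG (Homo sapiens), read by MTT assay, with a stated time of 48 h; a higher number here means a weaker inhibitor, a lower number a stronger inhibitor. Compound 2 `O=C(O[C@H]1C[C@H](n2cc(F)c(=O)[nH]c2=O)O[C@@H]1COP(=O)(O)Oc1ccc2ncccc2c1)c1ccccc1` gives 880 nM in this assay, and the step of a 1.2-fold higher number from compound 1 to compound 2 (0.09 log units; within the scatter) follows from the change (quinolin-6-yl in place of pyridin-3-yl on an oxygen). Compound 3 `O=c1[nH]c(=O)n([C@H]2C[C@H](O)[C@@H](COP(=O)(O)Oc3cccnc3)O2)cc1F` gives 39800 nM in this assay; the step of a 56-fold higher number from compound 1 to compound 3 (1.75 log units; beyond the scatter) corresponds to the core difference (hydrogen in place of benzoyl on an oxygen on a saturated carbon). Compound 4 `O=c1[nH]c(=O)n([C@H]2C[C@H](O)[C@@H](COP(=O)(O)Oc3ccc4ncccc4c3)O2)cc1F` has not been measured in this assay. It differs from compound 3 by quinolin-6-yl in place of pyridin-3-yl on an oxygen, the same change as seen between compound 1 and compound 2, at the same place in both pairs. The step from compound 3 to compound 4 is expected to be small, a 1.2-fold higher number from compound 3 to compound 4 (0.06 log units; within the scatter), because the earlier instance gave a 1.2-fold higher number from compound 1 to compound 2 (0.09 log units; within the scatter), a step within the scatter. On this basis compound 4 is estimated at 46000 nM in this assay, with a range from 20000 nM to 100000 nM.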

Compound 4, half-maximal inhibitory concentration: 10700 nM
Beside the measured number, compound 4's estimate is 4.3-fold (0.63 log units) above it; measured number outside the range, below it.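

On the core without benzoyl, quinolin-6-yl in place of pyridin-3-yl gives a 3.7-fold lower number from compound 3 to compound 4 (0.57 log units; beyond the scatter) in this assay, so this change does not carry over unchanged from the benzoyl-bearing core: the same change on two cores in this assay, a 1.2-fold higher number (0.09 log units; within the scatter) from compound 1 to compound 2 and a 3.7-fold lower number (0.57 log units; beyond the scatter) from compound 3 to compound 4, 4.6-fold (0.66 log units) apart, beyond the scatter of two such steps. Hydrogen in place of benzoyl still gives a 12-fold higher number from compound 2 to compound 4 (1.08 log units; beyond the scatter), but the size of that step depends on which of the two groups is present on the phosphate oxygen: the same change on two cores in this assay, a 56-fold higher number (1.75 log units; beyond the scatter) from compound 1 to compound 3 and a 12-fold higher number (1.08 log units; beyond the scatter) from compound 2 to compound 4, 4.6-fold (0.66 log units) apart, beyond the scatter of two such steps. These four compounds show that the two changes are not additive here; they do not show why, and they give no general rule for the series.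

Open, going by these compounds, is whether the same interplay appears with an acetyl group or a longer acyl chain in place of benzoyl. Also open, on these data alone, is the effect of an amine on the quinolin-6-yl group.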